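This account rests on a few compounds, and the source may have more. Where it says the series, first, only, none or still open, it means among the compounds named here.

Measured compounds:
compound 1 `CC1CCC(Nc2nc(C(F)(F)F)ccc2CNC(=O)C(C)c2ccc(NS(C)(=O)=O)c(F)c2)CC1`, in a functional assay on CHO-K1 cells for antagonist activity at transient receptor potential cation channel subfamily V member 1 (Homo sapiens), read by FLIPR (on this read-out higher numbers stand for weaker inhibition and lower numbers for stronger inhibition), compound 1 gives 27.2 nM;
compound 2 `Cc1ccc(Nc2nc(C(F)(F)F)ccc2CNC(=O)C(C)c2ccc(NS(C)(=O)=O)c(F)c2)cc1C`, in this assay compound 2 gives 39.3 nM.

Compound 2 has the higher of the two numbers, but the step of a 1.4-fold higher number from compound 1 to compound 2 (0.16 log units; within the scatter) lies within the scatter, so the two stand level. Compound 3 `CC(C(=O)NCc1ccc(C(F)(F)F)nc1NCc1ccccc1)c1ccc(NS(C)(=O)=O)c(F)c1` carries the change (benzyl in place of 3,4-dimethylphenyl on a nitrogen on an aromatic ring). Going by the values given here, no measured step covers an aryl-to-benzyl exchange at this nitrogen; the only known step there, a 1.4-fold higher number from compound 1 to compound 2 (0.16 log units; within the scatter), was flat. The step of a 2.0-fold higher number from compound 2 to compound 3 (0.31 log units; beyond the scatter) is therefore an estimate with wide bounds. Compound 3 is expected to give 80 nM in this assay, within 20 nM to 400 nM.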

Compound 3, inhibition constant: 15.8 nM
Beside the measured number, compound 3's estimate is 5.1-fold (0.70 log units) above it; measured number outside the range, below it.
By their numbers in this assay, from the lowest: compounds 3, 1 and 2 (each within the scatter of the next, the first and the last beyond it).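

At the nitrogen on an aromatic ring, benzyl gives stronger inhibition in this assay than 3,4-dimethylphenyl (a 2.5-fold lower number from compound 2 to compound 3 (0.40 log units; beyond the scatter)), whereas the earlier step at this position stayed within the scatter. Against 4-methylcyclohexyl, benzyl stands level (a 1.7-fold lower number from compound 1 to compound 3 (0.24 log units; within the scatter)), so only the two aromatic groups are separated here, and only narrowly. No evidence is at hand to account for this result.

The compounds shown leave open whether phenethyl, a longer chain, would hold this level at the nitrogen. They also leave open how a chlorine or a methoxy group on benzyl would read.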